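A few compounds are considered here, and "the series" means these few. Any claim that something is new, unique, unknown or untested is made for them only; others in the source may bear on it.

Series notes, antiproliferative read-out.

Compound 1 `CC/C=C\C(=O)Nc1cc(Nc2nc(C)cc(-c3cn(C)c4ccccc34)n2)c(OC)cc1N(C)CCN(C)C` and compound 2 `COc1cc(N(C)CCN(C)C)c(NC(=O)/C=C\C(C)C)cc1Nc1nc(C)cc(-c2cn(C)c3ccccc23)n1` share one core; compound 3 `CC/C=C\C(=O)Nc1cc(Nc2ncc(C#N)c(-c3cn(C)c4ccc(F)cc34)n2)c(OC)cc1N(C)CCN(C)C` and the not yet measured compound 4 `COc1cc(N(C)CCN(C)C)c(NC(=O)/C=C\C(C)C)cc1Nc1ncc(C#N)c(-c2cn(C)c3ccc(F)cc23)n1` share another. How the core of compound 3 differs from that of compound 1 is not broken down here.

In a functional assay on NCI-H1975 cells (Homo sapiens) for antiproliferative activity, read by MTT assay, with a stated time of 72 h (on this read-out higher numbers stand for weaker inhibition and lower numbers for stronger inhibition), compound 1 gives 1990 nM. Compound 2 gives 1230 nM in this assay. The change between them is methyl in place of hydrogen on a saturated chain carbon bound to a double-bonded chain carbon and a saturated chain carbon, and the step it made is a 1.6-fold lower number from compound 1 to compound 2 (0.21 log units; within the scatter), so the two numbers are not separated in any meaningful way.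

Compound 3 gives 10200 nM in this assay, the highest number among the three measured compounds; the gap to compound 1 and to compound 2 lies beyond the scatter in both cases.

Compound 4 carries the same change relative to compound 3, (methyl in place of hydrogen on a saturated chain carbon bound to a double-bonded chain carbon and a saturated chain carbon); the place is described in the same words as for compound 1 and compound 2, so this is the same change on a different core. It occurs twice among the compounds shown, once measured and once pending.

For compound 4 in this assay the expected step is a 1.6-fold lower number from compound 3 to compound 4 (0.20 log units; within the scatter), chosen to match what the same change made from compound 1 to compound 2 (a 1.6-fold lower number from compound 1 to compound 2 (0.21 log units; within the scatter)), which was within the scatter. Among the compounds with values here, because compound 3 gives 10200 nM, compound 4 is expected to give about 6500 nM, with a range estimated from 2500 nM to 17000 nM, since the one precedent is small and the core it is transferred to is different.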

Compound 4, half-maximal inhibitory concentration: 1130 nM
Beside the measured number, compound 4's estimate is 5.8-fold (0.76 log units) above it; the measured number lies below the stated range.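

In this assay the change from ethyl to isopropyl gives a 9.0-fold lower number from compound 3 to compound 4 (0.96 log units; beyond the scatter) and so moves the read-out towards stronger inhibition on the core of compound 3 by more than the scatter. The size of this step does not carry over from the core of compound 1, where the same change stayed within the scatter: the same change on two cores in this assay, a 1.6-fold lower number (0.21 log units; within the scatter) from compound 1 to compound 2 and a 9.0-fold lower number (0.96 log units; beyond the scatter) from compound 3 to compound 4, 5.6-fold (0.75 log units) apart, beyond the scatter of two such steps. In this series the outcome of the change therefore depends on the core that carries it, but the finding rests on a single pair per core and does not show which feature of the core is responsible or how the change would behave on a third core.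

The compounds shown leave open whether the larger step goes with the nitrile, with the fluorine or with another part of the core of compound 3, since no compound here separates these differences. Also open, as far as these compounds go, is how the read-out would respond on either core to a cyclopropyl, a tert-butyl or a longer chain in place of the isopropyl, or to an amine carried on that chain.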